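The compounds below may be only part of what the source reports. "The series", "measured", "known", "first", "only" and "open" are said of these compounds alone.

Measured compounds:
compound 1, `CC(C)=CCN(C1=NCCN1)c1c(Br)cccc1Br` — 10.8
compound 2, `C=C(C)CCN(C1=NCCN1)c1c(Br)cccc1Br` — 10.9

In a physicochemical assay for acid dissociation, compound 2 stands at the higher of the two numbers, with compound 1 within the scatter of it. Compound 3 `Brc1cccc(Br)c1N(Cc1ccco1)C1=NCCN1` remains to be measured. It differs from compound 2 in one place: furan-2-yl in place of 2-methylprop-2-en-1-yl on a saturated chain carbon bound to a nitrogen on an aromatic ring. For the measured compounds named here, the only measured step, a number 0.10 log units higher from compound 1 to compound 2 (within the scatter), exchanged one chain for another of the same length and moved nothing beyond the scatter. Going by the values given here, no measured step exchanges a chain for an aromatic ring or introduces a hydrogen-bond acceptor, so the bearing of that step on this change is limited. Compound 3 is therefore expected to change by a number 0.30 log units lower from compound 2 to compound 3 (within the scatter), an estimate of 10.6 within 10 to 11.1.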

Compound 3, acid dissociation constant: 10.5
The estimate for compound 3 lay 0.10 log units above the measured number; low and high end bracket the measured number.
By their numbers in this assay, from the lowest: compounds 3, 1 and 2 (each within the scatter of the next, the first and the last beyond it).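

For the compounds shown here, at this position, on a saturated chain carbon bound to a nitrogen on an aromatic ring, furan-2-yl in place of 2-methylprop-2-en-1-yl gives a number 0.40 log units lower from compound 2 to compound 3 (beyond the scatter) in this assay and is the first step here to pass the scatter. Measured against the other chain, furan-2-yl in place of 2-methylprop-1-en-1-yl gives a number 0.30 log units lower from compound 1 to compound 3 (within the scatter) and stays within it, so the ring's effect on the number remains modest and depends on the comparison. No evidence is available to explain this difference.

Going by these compounds, whether a phenyl ring or thiophene-2-yl would give a number like that of compound 3 stays open. So does what an amine on the chain would do.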